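Hydroxyethylamino substitution and cytotoxicity toward blood cells

The source may hold more compounds than are shown below. What is called first, only, known or untested is meant among the compounds shown, and "the series" means these compounds.

Compound 1 `CCOc1cc(C)cc2c1C(=O)C=C(c1c(C)cc3c(c1OCC)C(=O)C=CC3=O)C2=O`: 55500 nM
Compound 2 `COc1cc(C)cc2c1C(=O)C=C(c1c(C)cc3c(c1OC)C(=O)C(NCCO)=CC3=O)C2=O`: 21800 nM

Of the compounds shown here, two have so far been measured in an ADME assay on PBMC cells (Homo sapiens) for cytotoxicity, read by MTT assay, with a stated time of 24 h; a lower number here means a stronger inhibitor, a higher number a weaker inhibitor. Compound 1 gives 55500 nM, the higher of the two numbers, which makes it the weaker inhibitor of the pair. Compound 2 carries a (2-hydroxyethyl)amino group and differs from compound 1 in that group and in its two alkoxy groups. Compound 2 gives 21800 nM, a lower number that lies beyond the usual scatter of this assay.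

The step under consideration leads from compound 1 to compound 3 `CCOc1cc(C)cc2c1C(=O)C=C(c1c(C)cc3c(c1OCC)C(=O)C(NCCO)=CC3=O)C2=O`. The change is (2-hydroxyethyl)amino in place of hydrogen on a double-bonded ring carbon; everything else in the shared core stays as it is in compound 1. Going by the values given here, no step between two measured compounds matches this single change, so the expectation rests on compound 2, which shares the (2-hydroxyethyl)amino group with compound 3 but differs from it in its alkoxy groups. The step is expected to be a 2.5-fold lower number from compound 1 to compound 3 (0.40 log units; beyond the scatter), a lowering beyond the scatter, as compound 2 with that group present gives 21800 nM. Compound 3 is therefore estimated at 22000 nM, within a range from 9000 nM to 55000 nM.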

Compound 3, half-maximal inhibitory concentration: 65400 nM
The estimate for compound 3 lay 3.0-fold (0.47 log units) below the measured number, and the stated range ends below it.
By their numbers in this assay, from the lowest: compound 2; then compounds 1 and 3 (each within the scatter of the next).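

In this assay, going by these compounds alone, the change of (2-hydroxyethyl)amino in place of hydrogen on a double-bonded ring carbon can now be read directly for the first time, and it gives a 1.2-fold higher number from compound 1 to compound 3 (0.07 log units; within the scatter), so on the core of compound 1 the two compounds cannot be told apart at this position. The lower number of compound 2, at 21800 nM, therefore cannot be credited to the (2-hydroxyethyl)amino group alone, since that group on the ethoxy-bearing core has no effect beyond the scatter, and compound 2 differs from compound 3 in its alkoxy groups. Nothing measured here offers an explanation for this result.

The compounds shown leave open what the same change does when the two alkoxy groups are methoxy, as no partner of compound 2 with hydrogen on that carbon stands among them. They also leave open whether another substituent on that double-bonded ring carbon, such as a morpholine, a carboxylic acid or a longer hydroxyalkylamino chain, would separate from compound 1 in this assay.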